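The source may hold more compounds than are shown below. What is called first, only, known or untested is meant among the compounds shown, and "the series" means these compounds.

In a functional assay on the whole organism with Mus musculus as the target (a higher number here means that more compound is needed for the effect, a lower number that less compound is needed), compound 1 `NC(=O)/C=C/c1cccc(C(F)(F)F)c1` gives 42.9 mg/kg and compound 2 `CCNC(=O)/C=C/c1cccc(C(F)(F)F)c1` gives 90 mg/kg, the higher of the two numbers. Compound 3 `O=C(/C=C/c1cccc(C(F)(F)F)c1)NCCO` differs from compound 2 by hydroxy in place of hydrogen on a saturated chain carbon, two bonds along the chain from an amide-type nitrogen, which turns ethyl into 2-hydroxyethyl. For the measured compounds named here, only one measured step bears on this change, and it is modest and beyond the scatter: a 2.1-fold higher number from compound 1 to compound 2 (0.32 log units; beyond the scatter), with ethyl in place of hydrogen on an amide-type nitrogen. Going by the values given here, no measured step involves a hydroxy group, so that step sets only a rough scale, and the direction is uncertain. A small move toward a lower number, not beyond the scatter, is expected, namely a 1.5-fold lower number from compound 2 to compound 3 (0.18 log units; within the scatter). For compound 3 the estimated value is 60 mg/kg, with an expected range from 25 mg/kg to 140 mg/kg.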

Compound 3, dose for half-maximal effect: 117 mg/kg
Estimate against measurement, compound 3: 2.0-fold (0.29 log units) below; the range from low to high includes it.
By their numbers in this assay, from the lowest: compound 1; then compounds 2 and 3 (each within the scatter of the next).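

In this assay, hydroxy in place of hydrogen on a saturated chain carbon, two bonds along the chain from an amide-type nitrogen, gives a 1.3-fold higher number from compound 2 to compound 3 (0.11 log units; within the scatter) and so does not separate 2-hydroxyethyl from ethyl at this position. Against the unsubstituted amide, 2-hydroxyethyl gives a 2.7-fold higher number from compound 1 to compound 3 (0.44 log units; beyond the scatter) and thus stands on the same side of compound 1 as ethyl, which gives a 2.1-fold higher number from compound 1 to compound 2 (0.32 log units; beyond the scatter) in a step that is likewise modest. No measurement shown here offers an explanation for these numbers.

From the compounds shown here alone, whether an amine or a carboxylic acid at the end of the chain, or a longer chain, would also leave the number near those of compound 2 and compound 3 remains open. In this assay, going by these compounds, compound 1 gives 42.9 mg/kg and it is also open whether any group on this nitrogen can match that number or go lower.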